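The source may report more compounds than this note shows. Statements on the series, on what has been measured and on what is new or still open speak of the compounds shown alone.

Compound 2 `COc1cc(C(c2ccc(O)c(OC)c2)[C@@H](C)[C@H](C)CF)ccc1O` carries a 2-(fluoromethyl)-1-methylpropyl group on a saturated chain carbon bound to two aromatic carbons. In a functional assay on HeLa cells (Homo sapiens) for cytotoxicity, read by WST assay, with a stated time of 48 h (a higher number here means a weaker inhibitor, a lower number a stronger inhibitor), compound 2 gives 37000 nM. Of the two plain numbers measured, compound 2 stands highest, that is, as the weaker inhibitor. Its nearest neighbour is compound 1 `CCCCC[C@H](C(C)C)C(c1ccc(O)c(OC)c1)c1ccc(O)c(OC)c1`, which in this assay gives 9200 nM; the only measured single change among these compounds is a 4.0-fold higher number from compound 1 to compound 2 (0.60 log units; beyond the scatter). Compound 3 `COc1ccc(C(c2ccc(OC)c(OC)c2)[C@H](C)[C@H](C)CO)cc1OC` differs from both in more than one place, and in this assay compound 3 reaches only a limit, > 100000 nM, rather than a number.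

Compound 4 `COc1cc(C(c2ccc(O)c(OC)c2)[C@H](C)[C@@H](C)CO)ccc1O` is the next step from compound 2: 2-(hydroxymethyl)-1-methylpropyl in place of 2-(fluoromethyl)-1-methylpropyl on a saturated chain carbon bound to two aromatic carbons. Within the data shown here, no measured pair isolates this exchange. Among the measured compounds shown here, the one measured step, a 4.0-fold higher number from compound 1 to compound 2 (0.60 log units; beyond the scatter), concerns a different alteration of the same side chain and cannot be carried over directly. For the measured compounds named here, compound 3 shows only that a compound bearing a 2-(hydroxymethyl)-1-methylpropyl group sits at a limit, (the limit of > 100000 nM in this assay, at which 1 of the 3 values shown sits), while differing from compound 4 elsewhere as well. A modest weakening is therefore expected, a 1.6-fold higher number from compound 2 to compound 4 (0.21 log units; within the scatter), with a real chance that only a limit is reported. Compound 4 is estimated at 60000 nM, within 25000 nM to 150000 nM.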

Compound 4, half-maximal inhibitory concentration: > 100000 nM
Compound 4 ended at the assay's limit; the forecaster's own chance of this, stated with the estimate: 30%; middle value at least 1.6-fold (0.22 log units) away from the limit.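

In this assay, among these compounds, putting 2-(hydroxymethyl)-1-methylpropyl in place of 2-(fluoromethyl)-1-methylpropyl on a saturated chain carbon bound to two aromatic carbons gives an at least 2.7-fold higher number from compound 2 to compound 4 (0.43 log units; beyond the scatter), so this exchange, which no earlier pair isolated, weakens the compound beyond the scatter. Measured against the 1-isopropylhexyl group at the same place, the change is larger, with an at least 10-fold higher number from compound 1 to compound 4 (1.03 log units; beyond the scatter), and the three compounds with these side chains now fall in a clear order, with compound 1 the strongest and compound 4 the weakest. Compound 4 gives > 100000 nM, which is a limit of the assay and not a number, so both steps fix only a minimum size, and this limit now recurs: the limit of > 100000 nM in this assay, at which 2 of the 4 values shown sit.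

From the compounds shown here alone, how far compound 4 truly lies past that limit remains open, so the full size of both steps is unknown. Also open, going by these compounds, is how a 2-(aminomethyl)-1-methylpropyl group, or a carboxylic acid at the end of this side chain, would read in this assay.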